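Sulfonyl group change on the core of compound 1

The compounds below may be only part of what the source reports. "The series", "measured", "known", "first", "only" and "open" are said of these compounds alone.

Readings so far in a functional assay on Huh-7 cells (Homo sapiens) for cytotoxicity, read by MTT assay, with a stated time of 72 h; a higher number here means that more compound is tolerated, a lower number that less compound is tolerated 
- compound 1 `CS(=O)(=O)N1CCC2(CC1)OOC1(CCCCCC1)OO2` gives > 100 ug/mL 
- compound 2 `Cc1ccc(S(=O)(=O)N2CCC3(CC2)OOC2(CCCCC2)OO3)cc1` gives > 100 ug/mL 

Compound 1 stands only at the limit > 100 ug/mL of the assay, and no number is available for it. Compound 2 also gives a limit, > 100 ug/mL, and not a number. Together the two readings amount to the limit of > 100 ug/mL in this assay, at which 2 of the 2 values shown sit, and mark no order within the pair.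

Compound 3 `Cc1ccc(S(=O)(=O)N2CCC3(CC2)OOC2(CCCCCC2)OO3)cc1` is not yet measured. It differs from compound 1 by 4-methylphenyl in place of methyl on a sulfonyl sulfur, which is 4-methylphenyl in place of methyl on a sulfonyl sulfur.

Within the data shown here, no measured step bears on this change. In this assay no step beyond the usual scatter is expected, in either direction. The expected step of a number no higher from compound 1 to compound 3 (the limit leaves the size open) is therefore small. This expectation leans on compound 2, whose reading is the limit > 100 ug/mL in the same assay. A further limit is the likeliest report. For compound 3 the estimate is 100 ug/mL, with an expected range from 50 ug/mL to 200 ug/mL in this read-out.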

Compound 3, half-maximal cytotoxic concentration: > 100 ug/mL
Compound 3: a limit, no number; the forecaster's own chance of this, stated with the estimate: 75%; the middle value lies on the limit itself.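

In this assay compound 1 and compound 3 each give a limit and not a number, so no step can be read for 4-methylphenyl in place of methyl on a sulfonyl sulfur: the limit of > 100 ug/mL in this assay, at which 3 of the 3 values shown sit. The compounds shown leave open at what concentration any of them turns cytotoxic to these cells, and whether the sulfonyl group has any bearing on that concentration.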